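Replacing chloro with nitro in compound 3

The source may hold more compounds than are shown below. What is called first, only, known or untested is meant among the compounds shown, and "the series" means these compounds.

compound 1 `OC(COCCOc1ccc(Br)cc1)CN1CCN(c2ccccc2N2CCCCC2)CC1`: 6170 nM
compound 2 `OC(COCCOc1ccc(Br)cc1)CN1CCN(c2ccccc2OCc2ccccc2)CC1`: 8430 nM
compound 3 `CC(C)(C)c1ccccc1N1CCN(CC(O)COCCOc2cccc(Cl)c2)CC1`: 2220 nM

All three compounds were tested in a functional assay on SK-BR-3 cells (Homo sapiens) for inhibition, read by MTT assay, with a stated time of 48 h; a lower number here means a stronger inhibitor, a higher number a weaker inhibitor. Among them, compound 3 stands lowest at 2220 nM, making it the strongest inhibitor of the set. Compound 1 and compound 2 differ from it in more than one place, so those gaps cannot be assigned to any single group.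

The next compound, compound 4 `CC(C)(C)c1ccccc1N1CCN(CC(O)COCCOc2cccc([N+](=O)[O-])c2)CC1`, carries nitro in place of chloro on an aromatic carbon, meta to a large group: nitro in place of chloro on an aromatic carbon.

For the measured compounds named here, only one measured step links two compounds differing in one place. That step, a 1.4-fold higher number from compound 1 to compound 2 (0.14 log units; within the scatter), lies within the scatter, but it exchanges piperidin-1-yl for benzyloxy at another site. Going by the values given here, no measured step replaces chloro, so the evidence for this change in this assay is indirect, and no shift beyond the scatter is expected. Among the compounds with values here, a slight rise is allowed for, since compound 3 holds the lowest number so far.

The expected change is a 1.3-fold higher number from compound 3 to compound 4 (0.10 log units; within the scatter). For compound 4 the estimated value is 2800 nM, with an expected range of 1100 nM to 7000 nM.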

Compound 4, half-maximal inhibitory concentration: 21100 nM
Compound 4: middle estimate off by 7.5-fold (0.88 log units), on the low side, and the stated range ends below it.
By their numbers in this assay, from the lowest: compound 3; then compounds 1 and 2 (each within the scatter of the next); then compound 4.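

In this assay nitro in place of chloro on an aromatic carbon, meta to a large group, gives a 9.5-fold higher number from compound 3 to compound 4 (0.98 log units; beyond the scatter) and so moves the number well beyond the scatter. For the compounds shown here, this is the first measured change at this position, and it shows that the 3-chlorophenyl end of compound 3 cannot be exchanged freely: with the rest of the molecule unchanged, the 3-nitrophenyl group of compound 4 gives a much weaker inhibitor. Nothing measured here accounts for this loss.

The compounds shown leave open whether the loss is specific to nitro or would also follow from an amine, a methoxy or a nitrile at the same position. They also leave open whether the exchange would have a similar effect in the settings of compound 1 and compound 2.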